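This account rests on a few compounds, and the source may have more. Where it says the series, first, only, none or still open, it means among the compounds named here.

Compound 1 `CN(C)CCN1CCN(CC(=O)Nc2ccc(-c3nc4ccccc4o3)cc2)CC1` is the parent of the set. In a functional assay on HT-29 cells (Homo sapiens) for cytotoxicity, read by MTT assay, with a stated time of 24 h (a lower number here means a stronger inhibitor, a higher number a weaker inhibitor), compound 1 gives 5310 nM. Compound 2 `CN(C)CCN1CCN(CC(=O)Nc2ccc(-c3nc4cc(F)ccc4o3)cc2)CC1` carries fluoro in place of hydrogen on an aromatic carbon; in this assay compound 2 gives 8190 nM, and the step of a 1.5-fold higher number from compound 1 to compound 2 (0.19 log units; within the scatter) stays within the scatter, so the two numbers are not told apart. Compound 3 `Cc1cc(-c2nc3ccccc3o2)ccc1NC(=O)CN1CCN(CCCN(C)C)CC1` has a different core, and the difference between the core of compound 1 and the core of compound 3 is not broken down here. In this assay compound 3 gives 15500 nM; against compound 1 this is the one gap in the set beyond the scatter, while against compound 2 it lies within it. Compound 4 `Cc1cc(-c2nc3cc(F)ccc3o2)ccc1NC(=O)CN1CCN(CCCN(C)C)CC1` has not been measured. It carries fluoro in place of hydrogen on an aromatic carbon, the same change as that from compound 1 to compound 2, at the same place on the same ring system. Compound 4 is expected to give about 21000 nM in this assay, with an estimated range from 9000 nM to 50000 nM. This rests on compound 3 at 15500 nM and on the step of a 1.5-fold higher number from compound 1 to compound 2 (0.19 log units; within the scatter), which stayed within the scatter. The step of a 1.4-fold higher number from compound 3 to compound 4 (0.13 log units; within the scatter) is therefore expected to be small.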

Compound 4, half-maximal inhibitory concentration: 6700 nM
Compound 4: the middle estimate sits 3.1-fold (0.50 log units) above what was measured; measured number outside the range, below it.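

In this assay, fluoro in place of hydrogen gives a 2.3-fold lower number from compound 3 to compound 4 (0.36 log units; beyond the scatter), whereas on the core of compound 1 the same change gave a 1.5-fold higher number from compound 1 to compound 2 (0.19 log units; within the scatter). The change therefore does not carry over as one fixed step between these two cores, and the step read on one core is a poor guide to the step on the other: the same change on two cores in this assay, a 1.5-fold higher number (0.19 log units; within the scatter) from compound 1 to compound 2 and a 2.3-fold lower number (0.36 log units; beyond the scatter) from compound 3 to compound 4, 3.6-fold (0.55 log units) apart, beyond the scatter of two such steps This rests on a single pair for each core, so it shows that the outcome depends on the core here, but not which part of the core of compound 3 is responsible, nor any general rule for the series.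

As far as these compounds go, whether chloro or methoxy at the same place would follow the step on either core remains open. Also open, from the compounds shown here alone, is how the fluoro change reads on a core carrying only part of the difference between the core of compound 1 and the core of compound 3, which would help locate the source of the divergence.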